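The source may hold more compounds than are shown below. What is called first, only, known or untested is meant among the compounds shown, and "the series" means these compounds.

Measured so far, in a functional assay on HepG2 cells (Homo sapiens) for antiproliferative activity, read by MTT assay, with a stated time of 48 h; on this read-out lower numbers stand for stronger inhibition and higher numbers for weaker inhibition:

- compound 1 `C=CCN1C(=O)C(=O)c2cc(-c3ccc(OC)cc3)ccc21` gives 7090 nM
- compound 2 `COc1ccc(-c2ccc3c(c2)C(=O)C(=O)N3Cc2ccc(F)cc2)cc1` gives 1120 nM
- compound 3 `COc1ccc(-c2ccc3c(c2)C(=O)C(=O)N3Cc2cccc(Cl)c2)cc1` gives 320 nM

All three share one core and differ only in the group on a saturated chain carbon bound to an amide-type nitrogen in a ring. Compound 2 stands second highest of the three numbers: compound 3 lies a 3.5-fold lower number from compound 2 to compound 3 (0.54 log units; beyond the scatter), while compound 1 lies a 6.3-fold lower number from compound 1 to compound 2 (0.80 log units; beyond the scatter) in the other direction.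

Compound 4 `COc1ccc(-c2ccc3c(c2)C(=O)C(=O)N3Cc2ccc(OC)c(OC)c2)cc1` is not yet measured. It differs from compound 2 in this way: 3,4-dimethoxyphenyl in place of 4-fluorophenyl on a saturated chain carbon bound to an amide-type nitrogen in a ring. For the measured compounds named here, the steps that bear on it all concern the same place. Swapping vinyl for an aromatic ring gave a 6.3-fold lower number from compound 1 to compound 2 (0.80 log units; beyond the scatter) and a 22-fold lower number from compound 1 to compound 3 (1.35 log units; beyond the scatter), and swapping one aromatic ring for another gave a 3.5-fold lower number from compound 2 to compound 3 (0.54 log units; beyond the scatter). Going by the values given here, no step shows a 3,4-dimethoxyphenyl here, so from compound 2 to compound 4 a step of a 1.4-fold lower number from compound 2 to compound 4 (0.15 log units; within the scatter) is expected, which is within the scatter. Compound 4 is therefore estimated at 800 nM, between 250 nM and 2500 nM.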

Compound 4, half-maximal inhibitory concentration: 1350 nM
The estimate for compound 4 lay 1.7-fold (0.23 log units) below the measured number; low and high end bracket the measured number.
By their numbers in this assay, from the lowest: compound 3; then compounds 2 and 4 (each within the scatter of the next); then compound 1.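

In this assay, 3,4-dimethoxyphenyl brings 10 heavy atoms and 2 hydrogen-bond acceptors where 4-fluorophenyl has 7 and 0, yet the two compounds cannot be told apart (a 1.2-fold higher number from compound 2 to compound 4 (0.08 log units; within the scatter)), so this larger, differently substituted ring gives a number in line with the fluorinated one. This third aromatic ring also holds the advantage over vinyl (a 5.3-fold lower number from compound 1 to compound 4 (0.72 log units; beyond the scatter)), while 3-chlorophenyl keeps the lowest number of the four (a 4.2-fold higher number from compound 3 to compound 4 (0.63 log units; beyond the scatter)). No measurement at hand explains these steps.

The compounds shown leave open whether the lead of compound 3 depends on chlorine itself, which 3-bromophenyl or 4-chlorophenyl would test. They also leave open whether an aromatic ring is needed at all on this chain carbon, which cyclohexyl would test.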